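This account rests on a few compounds, and the source may have more. Where it says the series, first, only, none or still open, it means among the compounds named here.

Measured so far in an ADME assay on liver for metabolic stability, with Liver microsome (Rattus norvegicus) as the target, read by LC-MS, using microsomes, with a stated time of 5 h; on this read-out higher numbers stand for fast clearance and lower numbers for slow clearance:
Compound 1 `C[C@]1(O)C[C@@](c2cccc(C(F)(F)F)c2)([C@H](O)c2ccccn2)C1` gives 317 mL/min/kg.
Compound 2 `C[C@@]1(c2ccc(OC(F)(F)F)cc2)C[C@@](O)(c2ccccn2)CO1` gives 333 mL/min/kg.
Compound 3 `O[C@]1(c2ccccn2)CC[C@H](c2ccc(C(F)(F)F)cc2)C1` gives 1430 mL/min/kg.

Compound 2 stands second highest of these three numbers. Its nearest neighbour is compound 1, whose number is lower by a margin that lies within the usual scatter, so the two cannot be told apart on this read-out. Compound 3 sits furthest from compound 2, with a number higher by a margin beyond the scatter.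

Going by the values given here, compound 4 `C[C@@]1(c2ccc(OC(F)(F)F)cc2)C[C@](O)(c2ccccn2)CO1` is the compound still to be measured. the two compounds have the same atoms and bonds and differ only in configuration as drawn: 1 of 2 stereo elements differ; a stereocentre at a saturated ring carbon is drawn R in compound 2 and S in compound 4 No pair of measured compounds shows this kind of change, so the data give no direct guide to its size. The expectation in this assay is a step no larger than the usual scatter, in no fixed direction. Compound 4 is estimated at 350 mL/min/kg, with a range from 150 mL/min/kg to 800 mL/min/kg. The expected change is a 1.1-fold higher number from compound 2 to compound 4 (0.02 log units; within the scatter), which is expected to stay within the scatter.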

Compound 4, clearance: 383 mL/min/kg
For compound 4 the middle estimate is 1.1-fold (0.04 log units) below the measured one, and the stated range covers the measured number.
By their numbers in this assay, from the lowest: compounds 1, 2 and 4 (each within the scatter of the next); then compound 3.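

In this assay, the swap at the saturated ring carbon, drawn R in compound 2 and S in compound 4, gives a 1.2-fold higher number from compound 2 to compound 4 (0.06 log units; within the scatter). Going by these compounds alone, this is the first pair in the set that differs in one place, so for the first time the size of a single change can be read directly. The comparison isolates that one stereocentre, and it is clean because of a single feature of the pair: the fact that compounds 2 and 4 differ only in the configuration as drawn.

At this position, then, the configuration as drawn makes no difference that this assay can resolve. Still open, going by these compounds, is whether the same holds for the second stereo element, which this pair leaves unchanged, and whether it would hold on a shared core carrying an amine or a carboxylic acid.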